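A few compounds are considered here, and "the series" means these few. Any claim that something is new, unique, unknown or untested is made for them only; others in the source may bear on it.

Working notes on the series.

Three compounds carry numbers or verdicts in an assay on HEK293 cells for displacement of a labelled ligand from 5-hydroxytryptamine receptor 6 (Homo sapiens), with a stated time of 60 min, tested at 0.01 uM, in the presence of a further agent that is not named here; a lower number here means a weaker effect, a higher number a stronger effect of the compound at the concentration tested. Compound 1 `COc1cc(N)c(Cl)cc1C(=O)CCC1CCN(CCNS(=O)(=O)c2ccc3c(c2)NC(=O)CO3)CC1` and compound 2 `COc1ccc(S(=O)(=O)N2CCC(CCC(=O)c3cc(Cl)c(N)cc3OC)CC2)cc1` share the methoxy-chloro-aminophenyl ketone part of the core, but differ in how the sulfonamide is attached; in this assay compound 1 is reported as "not active" (no number reported), and in this assay compound 2 is likewise reported as "not active" (no number reported), with no number given for either. Going by the values given here, compound 3 `COc1cc(N)c(Cl)cc1C(=O)CCC1CCN(CCNS(=O)(=O)c2ccc(N)c(Br)c2)CC1` is the only member with a figure: in this assay compound 3 gives 39%. It therefore stands alone as the sole quantified point, and nothing can be said of its order relative to compound 1 or compound 2 beyond the fact that those two were called inactive.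

Compound 4 `COc1cc(N)c(Cl)cc1C(=O)CCC1CCN(CCNS(=O)(=O)c2cc(Br)c(N)c(Br)c2)CC1` is not yet measured. It differs from compound 3 as follows: bromo in place of hydrogen on an aromatic carbon. Among the compounds with values here, no step between measured compounds that differ in one place is available, so there is no precedent for this change. A second bromo ortho to the amino group is a small addition, and the expectation is a step of modest size, not clearly beyond the usual scatter, in either direction; a slight rise is taken as the central guess. The step from compound 3 to compound 4 is expected to be a number 6 percentage points higher from compound 3 to compound 4 (within the scatter). For compound 4 in this assay the estimate is 45%, with a range from 25% to 65%.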

Compound 4, a percentage reported as inhibition, at one concentration (the size of the read-out at that concentration, not a potency): 52%
Compound 4: the middle estimate sits 7 percentage points below what was measured; measured number inside the range.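

In a number 13 percentage points higher from compound 3 to compound 4 (beyond the scatter) under this assay, the series gains its first readable step between two compounds that differ in one place, here bromo in place of hydrogen on an aromatic carbon, ortho to an amino group. Going by these compounds alone, this position therefore accepts a second bromo with the read-out retained and raised, and the change from 4-amino-3-bromophenyl to 4-amino-3,5-dibromophenyl is the first structural change tied to a number, which the verdicts without figures on the earlier compounds could not provide. Nothing on hand speaks to why the read-out moves with this change.

The compounds shown leave open whether the rise belongs to bromo itself or would also follow from chloro, methyl or a nitrile on this same carbon, and whether the amino group is needed for it, as no compound shown replaces that amine with a hydroxyl or a hydrogen. Going by these compounds, since the read-out comes from a single concentration, the ranking of compound 3 and compound 4 by potency also stays open, and a full concentration series would be needed to settle it.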